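Changing the amide of a weak urea series

This account rests on a few compounds, and the source may have more. Where it says the series, first, only, none or still open, it means among the compounds named here.

Compound 1 `CNC(=O)/C=C/c1ccc(NC(=O)Nc2ccc(Cl)c(C(F)(F)F)c2)cc1`: 13800 nM
Compound 2 `CC(NC(=O)CCc1ccc(NC(=O)Nc2ccc(Cl)c(C(F)(F)F)c2)cc1)c1ccccc1`: > 50000 nM (a limit of the assay, not a number)
Compound 3 `O=C(CCc1ccc(NC(=O)Nc2ccc(Cl)c(C(F)(F)F)c2)cc1)NC1CCC1`: 24000 nM

All three compounds were tested in a functional assay on MX1 cells (Homo sapiens) for inhibition, read by MTT assay, with a stated time of 120 h; a higher number here means a weaker inhibitor, a lower number a stronger inhibitor. Worth keeping in view is the limit of > 50000 nM in this assay, at which 1 of the 3 values shown sits. Compound 3 stands close to compound 1, with a 1.7-fold higher number from compound 1 to compound 3 (0.24 log units; within the scatter), so these two cannot be told apart here.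

Compound 4 `CC1CN(C(=O)CCc2ccc(NC(=O)Nc3ccc(Cl)c(C(F)(F)F)c3)cc2)CC(C)O1` keeps the core of compound 3 and alters only the amide. The change is 2,6-dimethylmorpholin-4-yl in place of cyclobutylamino on a carbonyl carbon. Put simply, it is 2,6-dimethylmorpholin-4-yl in place of cyclobutylamino on a carbonyl carbon.

Among the measured compounds shown here, only one measured step touches this same amide: cyclobutyl in place of 1-phenylethyl gives an at least 2.0-fold lower number from compound 2 to compound 3 (0.31 log units; beyond the scatter). That step shows that the group at this amide can move the number, but it is modest, open-ended and a single case. It involves neither of the groups entering compound 4, so it offers only a weak guide. Little beyond the scatter is therefore expected in this assay, with a slight lean towards a higher number: the expected step is a 1.3-fold higher number from compound 3 to compound 4 (0.10 log units; within the scatter). The estimate for compound 4 is 30000 nM. The expected range runs from 13000 nM to 50000 nM.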

Compound 4, half-maximal inhibitory concentration: > 50000 nM
Compound 4 gave a limit, no number; the forecaster's own chance of this, stated with the estimate: 35%; middle value at least 1.6-fold (0.22 log units) from the limit.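

In this assay, 2,6-dimethylmorpholin-4-yl in place of cyclobutylamino on the carbonyl carbon gives an at least 2.0-fold higher number from compound 3 to compound 4 (0.31 log units; beyond the scatter), a second sign that the group on this amide can move the result. The loss seen with compound 2 is therefore not confined to its (1-phenylethyl)amino group, and among the three compounds with the saturated chain, only compound 3 still gives a number. On these data alone, compound 2 and compound 4 each give a limit, not a number, so the step between them cannot be read, and the true size of the step to compound 4 also stays unknown: the limit of > 50000 nM in this assay, at which 2 of the 4 values shown sit.

This single change swaps 1 hydrogen-bond donor for 0 and also replaces a four-membered ring of carbon only with a six-membered ring holding 2 hetero atoms, so the compounds shown cannot separate these differences. A piperidin-1-yl amide, which has no ring oxygen, or a plain morpholin-4-yl amide, which lacks the two methyl groups, would address that question, while a methylamino amide on the saturated chain would show how the chain itself compares with the ethenyl link in compound 1.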